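The source may hold more compounds than are shown below. What is called first, only, known or untested is meant among the compounds shown, and "the series" means these compounds.

Of the compounds shown here, two have been measured in an assay on isolated protein for inhibition of serine/threonine-protein kinase TNNI3K (Homo sapiens); on this read-out higher numbers stand for weaker inhibition and lower numbers for stronger inhibition. Compound 1, with the structure `CCNc1cc(Oc2ccc(NC(=O)Nc3cccc(C(F)(F)F)c3)cc2)ncn1`, carries an ethylamino group on the shared core and a trifluoromethyl on the outer phenyl ring of the urea; in this assay compound 1 gives 25 nM. Compound 2, with the structure `CNc1cc(Oc2ccc(NC(=O)Nc3ccccc3)cc2)ncn1`, carries a methylamino group instead and no trifluoromethyl; in this assay compound 2 gives 6300 nM. Compound 2 therefore stands at the highest number of the two, far beyond the usual scatter of repeated measurements, which means it is the weaker inhibitor. Compounds 1 and 2 differ in two places at once, so no single change can be read from that pair.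

Compound 3, with the structure `CNc1cc(Oc2ccc(NC(=O)Nc3cccc(C(F)(F)F)c3)cc2)ncn1`, differs from compound 2 in one place only: trifluoromethyl in place of hydrogen on an aromatic carbon, the place being meta to a large group. Compound 3 is expected to lie much closer to compound 1, because compound 1 with the same trifluoromethyl gives 25 nM. The step of a 110-fold lower number from compound 2 to compound 3 (2.02 log units; beyond the scatter) is expected to be large and toward stronger inhibition, well beyond the scatter. Compound 3 is estimated at 60 nM, with a likely range from 15 nM to 300 nM.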

Compound 3, half-maximal inhibitory concentration: 40 nM
Estimate against measurement, compound 3: 1.5-fold (0.18 log units) above, within the range that was stated.
By their numbers in this assay, from the lowest: compounds 1 and 3 (each within the scatter of the next); then compound 2.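

In this assay, within the data shown here, trifluoromethyl in place of hydrogen on an aromatic carbon, meta to a large group, gives a 160-fold lower number from compound 2 to compound 3 (2.20 log units; beyond the scatter); this is the first reading of a change at this position alone, and it shows that the position can carry a large difference in inhibition. The other change, hydrogen in place of methyl on a saturated chain carbon bound to a nitrogen on an aromatic ring, gives a 1.6-fold higher number from compound 1 to compound 3 (0.20 log units; within the scatter), so with the trifluoromethyl present, the ethylamino and methylamino groups cannot be told apart in this read-out. No measurement at hand gives a reason for either step.

The compounds shown leave open whether another group in the same place, such as a chlorine, a methyl or a nitrile, would give a step of similar size, or whether only trifluoromethyl does. They also leave open whether a chain longer than ethyl on the amino nitrogen, such as propyl or butyl, would still make no difference beyond the scatter, and whether the trifluoromethyl step would be as large with the ethylamino group in place.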